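The compounds below may be only part of what the source reports. "The series", "measured", "known", "first", "only" and "open" are said of these compounds alone.

In a functional assay on HL-60 cells (Homo sapiens) for inhibition (a lower number here means a stronger inhibitor, a higher number a weaker inhibitor), compound 1 `COc1cc(/C=C/c2ccc3ccccc3c2)cc(N)c1OC` gives 3150 nM, while compound 2 `COc1cc(/C=C\c2ccc3ccccc3c2)cc(N)c1OC` gives 330 nM. That is a 9.5-fold lower number from compound 1 to compound 2 (0.98 log units; beyond the scatter), and the two compounds differ only in the configuration of the double bond. Compound 3 `COc1c(N)cc(/C=C/c2ccc3ccccc3c2)cc1N` stands only at a limit, > 5000 nM. The measured step to it is an at least 1.5-fold higher number from compound 1 to compound 3 (0.20 log units; that floor lies within the scatter). Compound 4 `COc1c(N)cc(/C=C\c2ccc3ccccc3c2)cc1N` differs from compound 3 as follows: the two compounds have the same atoms and bonds and differ only in configuration as drawn: 1 of 1 stereo elements differ; a double bond is drawn E in compound 3 and Z in compound 4. Among the measured compounds shown here, the closest precedent is the same change in configuration, a 9.5-fold lower number from compound 1 to compound 2 (0.98 log units; beyond the scatter), so a step of similar size toward a lower number is expected, though it rests on a single pair. The expected change is an at least 6.2-fold lower number from compound 3 to compound 4 (0.79 log units; beyond the scatter). For compound 4, the estimated value is 800 nM, with an expected range of 200 nM to 4000 nM.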

Compound 4, half-maximal inhibitory concentration: 5000 nM
For compound 4 the middle estimate is 6.3-fold (0.80 log units) below the measured one, and the stated range ends below it.
By their numbers in this assay, from the lowest: compound 2; then compounds 1 and 4 (each within the scatter of the next).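

With the double bond drawn Z, amino in place of methoxy on an aromatic carbon now has a readable, large size in this assay: a 15-fold higher number from compound 2 to compound 4 (1.18 log units; beyond the scatter). Among the compounds shown here, the same change on the E compounds had given only a floor within the scatter, so this is the first sign that the change raises the number beyond the scatter. Compound 3 gives > 5000 nM, a limit of the assay. The size of the change in configuration on this core therefore cannot be read: a number no higher from compound 3 to compound 4 (the limit leaves the size open).

From the compounds shown here alone, it stays open whether the configuration matters as much on the core of compound 3 as on the core of compound 1. Going by these compounds, it also stays open how a hydroxy or ethoxy group would compare with methoxy and amino on an aromatic carbon of the Z compounds.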